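This account rests on a few compounds, and the source may have more. Where it says the series, first, only, none or still open, it means among the compounds named here.

Measured compounds:
Compound 1 `COc1cc(OCc2cccc(-c3ccc(C(F)(F)F)cn3)c2)c2cc(-c3cn4nc(OC)sc4n3)oc2c1`; in an ADME assay on the whole organism (Rattus norvegicus), at a dose of 2 mg/kg by the oral route (a higher number here means more compound in the circulation at the dose given, a lower number less compound in the circulation), compound 1 gives 459 ng.h/mL.
Compound 2 `CNC(=O)c1ccc(-c2nc(COc3cc(OC)cc4oc(-c5cn6nc(OC)sc6n5)cc34)cs2)cc1`; in this assay compound 2 gives 21.9 ng.h/mL.
Compound 3 `COc1cc(OCc2csc(-c3ccccc3)n2)c2cc(-c3cn4nc(OC)sc4n3)oc2c1`; in this assay compound 3 gives 3920 ng.h/mL.

Compound 1 stands second highest of the three numbers: compound 3 is higher and compound 2 is lower, both beyond the scatter. Going by the values given here, the only step between compounds that differ in one place is a 180-fold higher number from compound 2 to compound 3 (2.25 log units; beyond the scatter), which concerns hydrogen in place of methylcarbamoyl on an aromatic carbon and so does not touch the group changed here.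

Compound 4 `COc1ccc(-c2cccc(COc3cc(OC)cc4oc(-c5cn6nc(OC)sc6n5)cc34)c2)nc1` differs from compound 1 by methoxy in place of trifluoromethyl on an aromatic carbon. Among the compounds with values here, no measured step bears on this exchange; the one step in hand removed a different group on a different ring. With nothing to anchor a direction, the step of a 1.2-fold lower number from compound 1 to compound 4 (0.08 log units; within the scatter) is expected to stay within the scatter. Compound 4 is estimated at 380 ng.h/mL, with a range from 90 ng.h/mL to 1600 ng.h/mL in this assay.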

Compound 4, area under the concentration-time curve: 1700 ng.h/mL
For compound 4 the middle estimate is 4.5-fold (0.65 log units) below the measured one; measured number above the stated range.
By their numbers in this assay, from the lowest: compound 2; then compound 1; then compound 4; then compound 3.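

The 5-substituted pyridin-2-yl end of the side chain is not a silent position in this assay: the change from 5-(trifluoromethyl)pyridin-2-yl to 5-methoxypyridin-2-yl gives a 3.7-fold higher number from compound 1 to compound 4 (0.57 log units; beyond the scatter) and lies beyond the scatter. Going by these compounds alone, the earlier compounds offered no step at this position, so this is the first reading of a change here, and it concerns a single exchange on one core. No supporting measurement accounts for the direction of the step.

On these data alone, a single pair gives no trend, so it remains open how an amine, a carboxylic acid or a longer alkoxy chain would read at this position. As far as these compounds go, whether the same exchange would give a similar step on another side chain also remains open.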